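Chloro for Bromo on the Fused Ring of Compound 2

This account rests on a few compounds, and the source may have more. Where it says the series, first, only, none or still open, it means among the compounds named here.

Of the compounds shown here, two have been measured in a functional assay on cells (Cancer cell lines, Homo sapiens) for cytotoxicity, read by sulforhodamine B assay, with a stated time of 48 h; on this read-out higher numbers stand for weaker inhibition of growth and lower numbers for stronger inhibition of growth. Compound 1 `CN(C)c1ccc(C2CC(c3ccccc3)=NN2C2=NC(=O)/C(=C3\C(=O)Nc4ccccc43)S2)cc1` gives 1110 nM. Compound 2 `COc1ccc(-c2cc(-c3ccc(Cl)cc3)n(C3C(=O)Nc4ccc(Br)cc43)n2)cc1` gives 5480 nM, the higher of the two numbers, and its gap to compound 1 lies beyond the scatter. Compound 3 `COc1ccc(-c2cc(-c3ccc(Cl)cc3)n(C3C(=O)Nc4ccc(Cl)cc43)n2)cc1` has not been measured; it differs from compound 2 by chloro in place of bromo on an aromatic carbon. Going by the values given here, no measured pair shows this exchange, so in this assay the step is expected to be small, of no clear direction and within the scatter: a 1.0-fold higher number from compound 2 to compound 3 (0.00 log units; within the scatter). Compound 3 is accordingly estimated at 5500 nM, with a range from 2500 nM to 12000 nM.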

Compound 3, concentration for 50% growth inhibition: 3940 nM
Estimate against measurement, compound 3: 1.4-fold (0.14 log units) above, within the range that was stated.
By their numbers in this assay, from the lowest: compound 1; then compounds 3 and 2 (each within the scatter of the next).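

In this assay chloro in place of bromo on this aromatic carbon of the fused system gives a 1.4-fold lower number from compound 2 to compound 3 (0.14 log units; within the scatter) and so leaves the two halogens indistinguishable at this position, which compounds 1 and 2 alone could not show. Here, either halogen serves equally within the scatter. Nothing available explains why the two read alike.

From the compounds shown here alone, what remains open is whether a group of a different kind on this carbon, such as a carboxylic acid or an amine, would move the number beyond the scatter. The compounds shown also leave open whether the position needs a halogen at all.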